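A few compounds are considered here, and "the series" means these few. Any claim that something is new, unique, unknown or untested is made for them only; others in the source may bear on it.

Of the compounds shown here, three have been tested in a functional assay on IGROV-1 cells (Homo sapiens) for inhibition, read by sulforhodamine B assay, with a stated time of 48 h, tested at 1 uM; on this read-out lower numbers stand for a stronger effect and higher numbers for a weaker effect at the one concentration tested. Compound 1 `O=C(Nc1cccc(-n2cc(-c3ccncc3)c(-c3cc(O)cc(Cl)c3)n2)c1)Nc1ccc(Cl)c(C(F)(F)F)c1` gives 113%, and compound 2 `O=C(Nc1cccc(-n2cc(-c3ccncc3)c(-c3cc(O)cc(Cl)c3)n2)c1)Nc1ccc(Cl)c(Cl)c1` gives 95%. Compound 3 `COc1cc(Cl)cc(-c2nn(-c3cccc(NC(=O)Nc4cc(C(F)(F)F)cc(C(F)(F)F)c4)c3)cc2-c2ccncc2)c1` gives 33%, the lowest of the three numbers and thus the strongest effect seen so far; its nearest neighbour on the scale is compound 2, and compound 1 lies furthest away.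

The next compound, compound 4 `COc1cc(Cl)cc(-c2nn(-c3cccc(NC(=O)Nc4cccc(C(F)(F)F)c4)c3)cc2-c2ccncc2)c1`, is derived from compound 3 by a single change: hydrogen in place of trifluoromethyl on an aromatic carbon. Within the data shown here, the only measured step that touches a trifluoromethyl group is a number 18 percentage points lower from compound 1 to compound 2 (beyond the scatter), and it replaced that group with chloro rather than removing it. Among the measured compounds shown here, compound 3 also differs from compounds 1 and 2 in more than one place, so no step leads directly to it. The evidence is therefore thin, and it points, if anywhere, toward a weaker effect once one trifluoromethyl group is gone. The expected step is a number 27 percentage points higher from compound 3 to compound 4 (beyond the scatter), giving an estimate for compound 4 of 60%, within a range from 30% to 95%.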

Compound 4, a percentage reported as activity, at one concentration (the size of the read-out at that concentration, not a potency): 85%
For compound 4 the middle estimate is 25 percentage points below the measured one; the measured number falls inside the stated range.
By their numbers in this assay, from the lowest: compound 3; then compounds 4 and 2 (each within the scatter of the next); then compound 1.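

In this assay, taking away one of the two trifluoromethyl groups and leaving hydrogen gives a number 52 percentage points higher from compound 3 to compound 4 (beyond the scatter), so the read-out is highly sensitive to what sits at this position, meta to a trifluoromethyl group. Among these compounds, the one trifluoromethyl group that remains in compound 4 is not enough to keep the number near that of compound 3. Among the compounds shown here, the only earlier step involving this group, a number 18 percentage points lower from compound 1 to compound 2 (beyond the scatter), was a swap to chloro on a different compound, so this is the first look at simply removing it, and nothing measured here explains the size of the change.

From the compounds shown here alone, whether a methyl group or an amine at this position would hold the effect remains open. It is also unknown how the same removal would behave with the hydroxy group of compounds 1 and 2 in place of the methoxy group.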